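Forecasting cytotoxicity for compound 3

The source may report more compounds than this note shows. Statements on the series, on what has been measured and on what is new or still open speak of the compounds shown alone.

- Compound 1 `O=C(NCc1ccncc1)C1CCN(C(=O)c2cc3ccccc3n2Cc2ccc(Cl)cc2)CC1` gives > 100000 nM as a limit
- Compound 2 `Cn1cnc(CNC(=O)C2CCN(C(=O)c3cc4ccccc4n3Cc3ccc(Cl)cc3)CC2)c1` gives > 50000 nM as a limit

Both results come from an ADME assay on BE(2)-C cells (Homo sapiens) for cytotoxicity, read by MTT assay, with a stated time of 20 h (on this read-out higher numbers stand for lower toxicity in this test and lower numbers for higher toxicity in this test), and neither is a true number, so compound 2 stands only at a limit. Compound 3 `O=C(NCCCc1ccncc1)C1CCN(C(=O)c2cc3ccccc3n2Cc2ccc(Cl)cc2)CC1` carries 2-(pyridin-4-yl)ethyl in place of 1-methyl-1H-imidazol-4-yl on a saturated chain carbon bound to an amide-type nitrogen, counted as 2-(pyridin-4-yl)ethyl in place of 1-methyl-1H-imidazol-4-yl on a saturated chain carbon bound to an amide-type nitrogen here. Among the compounds with values here, the one measured step that the two limits leave unreadable from compound 1 to compound 2 has no readable size, so it gives no direction. The estimated step runs a step that the limit leaves unreadable from compound 2 to compound 3 and no clear change is expected. In this assay the expected value for compound 3 is 80000 nM within an estimated range from 25000 nM to 200000 nM as a rough guide.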

Compound 3, half-maximal cytotoxic concentration: 71500 nM
Estimate against measurement, compound 3: 1.1-fold (0.05 log units) above, within the range that was stated.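

In this assay compound 3 is the first of the compounds shown to give a true number rather than a limit. Putting 2-(pyridin-4-yl)ethyl in place of pyridin-4-yl gives an at least 1.3-fold lower number from compound 1 to compound 3 (0.14 log units; that floor lies within the scatter) and so shows no change beyond the scatter, though a larger one stays possible. Compound 1 stands only at a limit: the limit of > 100000 nM in this assay, at which 1 of the 3 values shown sits.

The steps that involve compound 2 cannot be read. As far as these compounds go, what a longer chain, or a carboxylic acid in place of the pyridine ring, would do at this place remains open.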